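A few compounds are considered here, and "the series" means these few. Any claim that something is new, unique, unknown or untested is made for them only; others in the source may bear on it.

In a functional assay on HCT-8 cells (Homo sapiens) for antiproliferative activity, read by MTT assay, with a stated time of 48 h (on this read-out lower numbers stand for stronger inhibition and higher numbers for weaker inhibition), the measured compounds are:

compound 1, `COc1ccc(C(=O)c2ccc(OC)c3c2OC(C)(C)C=C3)c(NC(=O)CO)c1`, 230 nM
compound 2, `COc1ccc(C(=O)c2ccc(OC)c3c2OC(C)(C)C=C3)c(NC(=O)CN)c1`, 370 nM
compound 3, `C=C(c1cc(OC)c(OC)c(OC)c1)c1ccc(OC)cc1NC(=O)CO`, 40 nM

Compound 2 differs from compound 1 by amino in place of hydroxy on a saturated chain carbon bound to a carbonyl carbon. The step of a 1.6-fold higher number from compound 1 to compound 2 (0.21 log units; within the scatter) is within the scatter, so the two values show no change that can be read as real.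

Compound 3 is built on a different core; the difference between the core of compound 3 and that of compound 1 is not broken down here. Its value in this assay stands lowest of the three, and the gaps to compound 1 and to compound 2 are both beyond the scatter.

Compound 4, `C=C(c1cc(OC)c(OC)c(OC)c1)c1ccc(OC)cc1NC(=O)CN`, is not yet measured. It differs from compound 3 by amino in place of hydroxy on a saturated chain carbon bound to a carbonyl carbon, the same change at the same place as that from compound 1 to compound 2. The step is expected to be small, a 1.5-fold higher number from compound 3 to compound 4 (0.18 log units; within the scatter), because a 1.6-fold higher number from compound 1 to compound 2 (0.21 log units; within the scatter) was within the scatter. Compound 4 is therefore estimated at 60 nM in this assay, with a likely range from 25 nM to 150 nM.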

Compound 4, half-maximal inhibitory concentration: 60 nM
Compound 4: middle estimate and measured number agree at the digits printed, and the stated range covers the measured number.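

In this assay, amino in place of hydroxy on a saturated chain carbon bound to a carbonyl carbon gives a 1.5-fold higher number from compound 3 to compound 4 (0.18 log units; within the scatter), and the change reads alike on the two cores: the same change on two cores in this assay, a 1.6-fold higher number (0.21 log units; within the scatter) from compound 1 to compound 2 and a 1.5-fold higher number (0.18 log units; within the scatter) from compound 3 to compound 4, 1.1-fold (0.03 log units) apart, within the scatter of two such steps

Across these two cores, then, the swap of hydroxymethyl to aminomethyl carries over with no step that can be told from the scatter, and the two steps cannot be told apart either. This does not show that the two groups are interchangeable on any further core, and with both steps inside the scatter, a small real difference can be neither claimed nor ruled out.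

The compounds shown leave open whether other groups at this place, such as a dimethylamino group, a carboxylic acid or a longer chain carrying the amino group, would read the same way. Also open, going by these compounds, is whether the match between hydroxy and amino holds in cell lines other than this one.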